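The compounds below may be only part of what the source reports. "The series", "measured", "known", "first", "only" and "open" are said of these compounds alone.

Working notes on the series. The shared core is that of compound 1 `CCOc1cc(C#N)cc(OCC)c1Oc1nc(Nc2ccc(C#N)cc2)nc2ccccc12`; in an ADME assay on MT4 cells (Homo sapiens) for cytotoxicity, read by MTT assay, with a stated time of 4 days (a higher number here means that more compound is tolerated, a lower number that less compound is tolerated), compound 1 gives 108000 nM. Compound 2 `CCCOc1cc(C#N)cc(OCC)c1Oc1nc(Nc2ccc(C#N)cc2)nc2ccccc12` gives 123000 nM in this assay. Compound 3 `COc1cc(C#N)cc(Cl)c1Oc1nc(Nc2ccc(C#N)cc2)nc2ccccc12` gives 220000 nM in this assay, the top number of the three, although its gap to compound 2 is within the scatter; only its gap to compound 1 lies beyond the scatter.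

Among the compounds with values here, the single measured step that lengthens an alkoxy chain, a 1.1-fold higher number from compound 1 to compound 2 (0.06 log units; within the scatter), stays within the scatter. Compound 4 `CCOc1cc(C#N)cc(Cl)c1Oc1nc(Nc2ccc(C#N)cc2)nc2ccccc12` differs from compound 3 by methyl in place of hydrogen on a saturated chain carbon bound to an oxygen on an aromatic ring; the same difference, cut one bond further out, reads methyl to ethyl, methoxy to ethoxy. Because a 1.1-fold higher number from compound 1 to compound 2 (0.06 log units; within the scatter) did not move beyond the scatter, no step beyond the scatter is expected here in either direction, and the expected step of a 1.1-fold lower number from compound 3 to compound 4 (0.04 log units; within the scatter) is set accordingly. For compound 4 the estimate in this assay is 200000 nM, with a range from 100000 nM to 400000 nM.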

Compound 4, half-maximal cytotoxic concentration: 22000 nM
For compound 4 the middle estimate is 9.1-fold (0.96 log units) above the measured one, and the stated range ends above it.
By their numbers in this assay, from the lowest: compound 4; then compounds 1, 2 and 3 (each within the scatter of the next, the first and the last beyond it).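

In this assay, lengthening the alkoxy chain is not a silent change on the chloro-bearing core, where methoxy to ethoxy gives a 10-fold lower number from compound 3 to compound 4 (1.00 log units; beyond the scatter). The effect of this one-carbon extension therefore depends on the core and does not carry over from one to the other: the same change on two cores in this assay, a 1.1-fold higher number (0.06 log units; within the scatter) from compound 1 to compound 2 and a 10-fold lower number (1.00 log units; beyond the scatter) from compound 3 to compound 4, 11-fold (1.06 log units) apart, beyond the scatter of two such steps
Chloro in place of propoxy, a 5.6-fold lower number from compound 2 to compound 4 (0.75 log units; beyond the scatter), and chloro in place of ethoxy, a 4.9-fold lower number from compound 1 to compound 4 (0.69 log units; beyond the scatter), point the same way, and both are read with an ethoxy group retained.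

The compounds shown leave open whether a propoxy or longer chain on the core of compound 4 lowers the number further or restores it, and whether an amine at that position follows the alkoxy groups. They also do not tell why the two cores respond so differently to the same change.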